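This account rests on a few compounds, and the source may have more. Where it says the series, first, only, none or still open, it means among the compounds named here.

Working notes on the arylsulfonyl series.

Two members have been measured in a functional assay on CHO cells for antagonist activity at 5-hydroxytryptamine receptor 6 (Homo sapiens), read by luminescence and cAMP accumulation; a higher number here means a weaker inhibitor, a lower number a stronger inhibitor. Compound 1, `CCN1CCN(c2cn(S(=O)(=O)c3ccc(F)cc3)c3ccc(Cl)cc23)CC1`, gives 1780 nM in this assay. Compound 2, `CN1CCN(c2cn(S(=O)(=O)c3ccc(F)cc3)c3ccc(Br)cc23)CC1`, gives 1530 nM in this assay. Compound 2 holds the lower of the two numbers, but the gap to compound 1 lies within the scatter of the method, so the two cannot be ranked against each other; both sit in the same region of weak inhibition.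

Compound 3, `CN1CCN(c2cn(S(=O)(=O)c3cccc(Cl)c3)c3ccc(Br)cc23)CC1`, is the next member and awaits measurement in this assay. It differs from compound 2 only at the group on the sulfonyl sulfur: 3-chlorophenyl in place of 4-fluorophenyl on a sulfonyl sulfur. The sulfonyl sulfur keeps its other neighbour, the aromatic nitrogen of the shared core, and the rest of the molecule is unchanged.

For the measured compounds named here, no step between measured compounds gives a direct guide for this exchange, so the expectation rests on the two values alone. The step is expected to be small, a 1.3-fold lower number from compound 2 to compound 3 (0.11 log units; within the scatter), leaning if anything towards a somewhat lower number, but a result within the scatter of compound 2 would not surprise. Compound 3 is expected to give about 1200 nM in this assay, with a plausible range from 400 nM to 3500 nM.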

Compound 3, half-maximal inhibitory concentration: 322 nM
Compound 3: the middle estimate sits 3.7-fold (0.57 log units) above what was measured; measured number below the stated range.
By their numbers in this assay, from the lowest: compound 3; then compounds 2 and 1 (each within the scatter of the next).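

For the compounds shown here, the group on the sulfonyl sulfur is the first place where a single exchange is seen to move the number beyond the scatter: in this assay, 3-chlorophenyl in place of 4-fluorophenyl gives a 4.8-fold lower number from compound 2 to compound 3 (0.68 log units; beyond the scatter) and brings the series out of the region of weak inhibition held by the earlier members. The two groups match in heavy-atom count, in their single aromatic ring of carbon only and in their lack of hydrogen-bond donors and acceptors, yet the halogen and its numbered place on the phenyl ring both differ, so this one step cannot be split between those two changes. Nothing at hand bears on why the number falls.

Still open, as far as these compounds go, is whether 4-chlorophenyl or 3-fluorophenyl on the sulfonyl sulfur would separate those two changes, and whether a halogen is needed at all, as unsubstituted phenyl or 3-methoxyphenyl would show. Also open, from the compounds shown here alone, is whether the same exchange gives a step of like size on the core of compound 1.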